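Defining the cyclopropylamine stereocentres: compound 1 to compound 3

This account rests on a few compounds, and the source may have more. Where it says the series, first, only, none or still open, it means among the compounds named here.

Of the compounds shown here, two of the shared core have been measured so far. Compound 1 `CNC(=O)[C@]12C[C@@H]1[C@@H](n1cnc3c(NC4CC4c4ccc(F)c(F)c4)nc(C#Cc4cccc(F)c4)nc31)[C@H](O)[C@@H]2O` was tested in an assay on isolated protein for binding affinity to adenosine receptor A3 (Homo sapiens); a higher number here means a weaker inhibitor, a lower number a stronger inhibitor. For compound 1 the result is a limit of the assay and not a number, >= 99 nM. Compound 2 `CNC(=O)[C@]12C[C@@H]1[C@@H](n1cnc3c(NCc4cccc(Cl)c4)nc(C#Cc4ccccc4)nc31)[C@H](O)[C@@H]2O` likewise gives only a limit in this assay, >= 99 nM. What the numbers show is summarised in the limit of >= 99 nM in this assay, at which 2 of the 2 values shown sit. Going by the values given here, compound 1 therefore stands at the limit, with no measured number to place it in order against compound 2, and no step between measured compounds can be read.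

Compound 3 `CNC(=O)[C@]12C[C@@H]1[C@@H](n1cnc3c(N[C@H]4C[C@@H]4c4ccc(F)c(F)c4)nc(C#Cc4cccc(F)c4)nc31)[C@H](O)[C@@H]2O` is not yet measured in this assay. It keeps all atoms and bonds of compound 1 and differs only in drawn configuration: the two compounds have the same atoms and bonds; at least one stereo element is drawn with a configuration in one of them and without one in the other: 2 of 7 stereo elements differ; a stereocentre at a saturated ring carbon is drawn without a configuration in compound 1 and S in compound 3; a stereocentre at a saturated ring carbon is drawn without a configuration in compound 1 and R in compound 3. Without a measured step the size of the change cannot be taken from the data. The expectation is a step that the limit leaves unreadable from compound 1 to compound 3 of modest size, most likely leaving compound 3 near the limit. Compound 3 is estimated at 150 nM, within 40 nM to 600 nM, with a fair chance that this assay again reports only a limit.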

Compound 3, inhibition constant: >= 99 nM
Compound 3: no number, only a limit; the forecaster's own chance of this, stated with the estimate: 55%; the middle value does not contradict the limit.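

No step from compound 1 to compound 3 can be read in this assay, since neither result is a number: the limit of >= 99 nM in this assay, at which 3 of the 3 values shown sit.

The compounds shown leave open whether the drawn S and R configurations at the two saturated ring carbons of compound 3 change the affinity of compound 1 at all, and how the three compounds rank.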